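Thiophene for furan on a dihydropyrimidinone ester

A few compounds are considered here, and "the series" means these few. Any claim that something is new, unique, unknown or untested is made for them only; others in the source may bear on it.

In an assay on membranes from HEK293 cells for displacement of a labelled ligand from adenosine receptor A2b (Homo sapiens), read by scintillation counting, with a stated time of 30 min (a higher number here means a weaker inhibitor, a lower number a stronger inhibitor), compound 1 `CCCOC(=O)C1=C(C)NC(=O)NC1c1ccoc1` gives 1190 nM, and compound 2 `CC1=C(C(=O)OCC(C)C)C(c2ccoc2)NC(=O)N1` gives 326 nM, the lower of the two numbers; the step of a 3.7-fold lower number from compound 1 to compound 2 (0.56 log units; beyond the scatter) separates them. Compound 3 `CC1=C(C(=O)OCC(C)C)C(c2cccs2)NC(=O)N1` differs from compound 2 by thiophen-2-yl in place of furan-3-yl on a saturated ring carbon. No measured step touches this ring exchange; the only step shown concerns the ester chain and cannot guide it. The step from compound 2 to compound 3 in this assay is therefore expected to stay within the scatter, at about a 1.0-fold higher number from compound 2 to compound 3 (0.01 log units; within the scatter). Compound 3 is estimated at 330 nM, ranging from 100 nM to 1100 nM.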

Compound 3, inhibition constant: 2130 nM
Compound 3: the middle estimate sits 6.5-fold (0.81 log units) below what was measured; measured number outside the range, above it.
By their numbers in this assay, from the lowest: compound 2; then compounds 1 and 3 (each within the scatter of the next).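

In this assay, the position on the saturated ring carbon proves sensitive to the exchange of one aromatic ring for another: thiophen-2-yl in place of furan-3-yl gives a 6.5-fold higher number from compound 2 to compound 3 (0.82 log units; beyond the scatter), although both groups have the same heavy-atom count and the same count of hydrogen-bond acceptors. Nothing available explains this difference. The compounds shown leave open whether the hetero atom or the ring's point of attachment matters, which thiophen-3-yl or furan-2-yl on this carbon would separate. On these data alone, how a phenyl ring would fare here also remains open.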